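This account rests on a few compounds, and the source may have more. Where it says the series, first, only, none or still open, it means among the compounds named here.

Measured compounds:
Compound 1, `O=C1O/C(=C\Cn2cc(Cl)c(=O)[nH]c2=O)C(OCc2ccccc2)=C1OCc1ccccc1`, gives 12200 nM in an ADME assay on L1210/0 cells (Mus musculus) for cytotoxicity, with a stated time of 48 h; a higher number here means a weaker inhibitor, a lower number a stronger inhibitor.
Compound 2, `O=c1[nH]c(=O)n(C[C@H]2CCC[C@H]2CO)cc1I`, gives only the limit > 200000 nM in this assay.
Compound 3, `C[S+]([O-])c1cn([C@H]2C[C@H](O)[C@@H](CO)O2)c(=O)[nH]c1=O`, gives only the limit > 200000 nM in this assay.

Compound 3 therefore has no number of its own in this assay; it sits at a limit, and so does one of the other two values shown, as the limit of > 200000 nM in this assay, at which 2 of the 3 values shown sit, notes. Only compound 1 has a proper number, and no step between compounds that differ in a single place has been measured, so there is nothing in the shown data that tells how a change at this position moves the read-out.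

Compound 4, `O=c1[nH]c(=O)n([C@H]2C[C@H](O)[C@@H](CO)O2)cc1O`, is the next compound to be measured. It differs from compound 3 in one place: one oxygen atom in place of a group of 3 heavy atoms (1 carbon, 1 oxygen, 1 sulfur; no ring), on an aromatic carbon. Since compound 3 itself is at a limit, the step from compound 3 to compound 4 cannot be pinned down; the author expects either no change beyond the scatter or a modest gain in potency, and the step of an at least 1.6-fold lower number from compound 3 to compound 4 (0.22 log units; that floor lies within the scatter) expresses that expectation. Compound 4 is accordingly estimated at 120000 nM in this assay, with a range from 25000 nM to 200000 nM, and a fair chance that the assay again reports only a limit.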

Compound 4, half-maximal inhibitory concentration: > 200000 nM
Compound 4 ended at the assay's limit; the forecaster's own chance of this, stated with the estimate: 45%; middle value at least 1.6-fold (0.22 log units) from the limit.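

Compound 3 and compound 4 both sit at a limit in this assay, not at a number, so the step between them cannot be read. The compounds shown leave open whether any group on this aromatic carbon moves the read-out at all, since the values for both compounds stop at the same point: the limit of > 200000 nM in this assay, at which 3 of the 4 values shown sit.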